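A few compounds are considered here, and "the series" means these few. Any claim that something is new, unique, unknown or untested is made for them only; others in the source may bear on it.

Measured so far:
- compound 1 `COc1cccc(CNCCCNc2ccnc3cc(Oc4ccccc4)ccc23)c1O` gives 14500 nM in a physicochemical assay for solubility, with a stated time of 18 h, at pH 7.4; on this read-out lower numbers stand for lower solubility and higher numbers for higher solubility
- compound 2 `CN(C)c1cccc(Oc2ccc3c(NCCCNCc4ccco4)ccnc3c2)c1` gives 14500 nM in this assay
- compound 3 `COc1cccc(CNCCCNc2ccnc3cc(Cc4ccc(F)cc4)ccc23)c1O` gives 4200 nM in this assay

Compound 3 shows the lowest of the three numbers. Compounds 1 and 2 share the same number, and each sits beyond the scatter above compound 3. Compound 4 `COc1cccc(CNCCCNc2ccnc3cc(Oc4cccc(N(C)C)c4)ccc23)c1O` is the next compound, not yet measured. It is made from compound 3 by one change: 3-(dimethylamino)phenoxy in place of 4-fluorobenzyl on an aromatic carbon.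

Going by the values given here, one measured step bears on this change. Going from compound 1 to compound 3 swapped phenoxy for 4-fluorobenzyl at the same position and gave a 3.5-fold lower number from compound 1 to compound 3 (0.54 log units; beyond the scatter). Compound 4 reverses that swap and carries a 3-(dimethylamino)phenoxy, the group also present in compound 2, whose number matches compound 1. A step back upward is therefore expected for compound 4, of about the same size, as a 3.5-fold higher number from compound 3 to compound 4 (0.54 log units; beyond the scatter). On that basis compound 4 is estimated at 14500 nM, with a range from 6000 nM to 32000 nM.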

Compound 4, solubility: 14500 nM
Beside the measured number, compound 4's estimate shows no gap at the digits printed, and the stated range covers the measured number.
By their numbers in this assay, from the lowest: compound 3; then compounds 1, 2 and 4 (each within the scatter of the next).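

In this assay, 3-(dimethylamino)phenoxy in place of 4-fluorobenzyl on the aromatic carbon restores the higher number (a 3.5-fold higher number from compound 3 to compound 4 (0.54 log units; beyond the scatter)), so the step seen with plain phenoxy now appears with a second phenoxy group. Dimethylamino in place of hydrogen on that phenoxy ring leaves the number where it was (no change at the digits printed from compound 1 to compound 4 (within the scatter)), which the earlier compounds could not show. With this phenoxy group held constant, 2-hydroxy-3-methoxyphenyl in place of furan-2-yl on the saturated chain carbon bound to an amine nitrogen also makes no difference beyond the scatter (no change at the digits printed from compound 2 to compound 4 (within the scatter)).

Nothing at hand explains these numbers. From the compounds shown here alone, whether a carboxylic acid on the phenoxy ring, or a longer chain in place of the saturated one, would shift the number remains open.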